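This account rests on a few compounds, and the source may have more. Where it says the series, first, only, none or still open, it means among the compounds named here.

In a functional assay on Jurkat cells (Homo sapiens) (a lower number here means a stronger inhibitor, a higher number a weaker inhibitor), compound 1 (`CC(C)[C@H](NC(=O)COc1cccc2ccccc12)C(=O)N[C@@H](CC(=O)O)C(=O)COc1ccccc1`) gives 14000 nM, and compound 2 (`CC(C)[C@H](NC(=O)COc1cccc2ccccc12)C(=O)N[C@@H](CC(=O)O)C(=O)COc1ccc(-c2ccccc2)cc1`) gives 87900 nM. Compound 3 (`CC(C)[C@H](NC(=O)COc1cccc2ccccc12)C(=O)N[C@@H](CC(=O)O)C(=O)COc1ccc(C(N)=O)cc1`) reads > 100000 nM, which is a limit of the assay and not a number. Compound 4 (`CC(C)[C@H](NC(=O)COc1cccc2ccccc12)C(=O)N[C@@H](CC(=O)O)C(=O)COc1cccc(F)c1`) differs from it by 3-fluorophenyl in place of 4-carbamoylphenyl on an oxygen on a saturated carbon, with 3-fluorophenyl in place of 4-carbamoylphenyl on an oxygen on a saturated carbon. Within the data shown here, two measured steps bear on this change. Carbamoyl in place of hydrogen gave an at least 7.1-fold higher number from compound 1 to compound 3 (0.85 log units; beyond the scatter), and phenyl in place of hydrogen gave a 6.3-fold higher number from compound 1 to compound 2 (0.80 log units; beyond the scatter). Compound 4 carries neither group, so it is expected to sit near compound 1 at 14000 nM. A lower number is therefore expected, with an estimated step of an at least 6.2-fold lower number from compound 3 to compound 4 (0.79 log units; beyond the scatter). Compound 4 is estimated at 16000 nM, within an expected range from 5000 nM to 50000 nM.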

Compound 4, half-maximal inhibitory concentration: > 100000 nM
Compound 4 gave a limit, no number (the forecaster's own chance of this, stated with the estimate: 3%); at least 6.2-fold (0.79 log units) between middle value and limit.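

In this assay, the added fluoro gave an at least 7.1-fold higher number from compound 1 to compound 4 (0.85 log units; beyond the scatter), so among the compounds shown, the unsubstituted phenyl of compound 1 alone reads below the limit, and a loss appears with 3-fluorophenyl as well as with the 4-substituted groups. The step of an at least 1.1-fold higher number from compound 2 to compound 4 (0.05 log units; that floor lies within the scatter) has a floor within the scatter and sets no order. Compound 3 and compound 4 both sit at a limit, so the step between them cannot be read: the limit of > 100000 nM in this assay, at which 2 of the 4 values shown sit. From the compounds shown here alone, whether a methoxy or an amine in place of the fluoro would stay near compound 1 remains open.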